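This account rests on a few compounds, and the source may have more. Where it says the series, first, only, none or still open, it means among the compounds named here.

Measured in a functional assay on MDA-MB-231 cells (Homo sapiens) for antiproliferative activity, with a stated time of 48 h; a higher number here means a weaker inhibitor, a lower number a stronger inhibitor:
- compound 1 `CCN(CC)c1ccc(-c2cccc(OC)c2)nn1`: > 25000 nM
- compound 2 `CCN(CC)c1ccc(-c2ccc(C#N)cc2)nn1`: > 25000 nM

Compound 1 stands at the limit of > 25000 nM in this assay, at which 2 of the 2 values shown sit. This entry is a limit of the assay and not a number, so it gives no exact starting point. The entry for compound 2 is also a limit.

Compound 3 `CCOC(=O)c1cccc(-c2ccc(N(CC)CC)nn2)c1` has not yet been measured. It differs from compound 1 in one place, where ethoxycarbonyl stands in place of methoxy on an aromatic carbon, meta to a large group: ethoxycarbonyl in place of methoxy on an aromatic carbon.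

Within the data shown here, no step between two measured compounds is available as a guide, so the expectation here is cautious. Among the measured compounds shown here, the only evidence is that compound 1 and compound 2 both stop at the limit, and compound 3 is expected to behave in the same way. No change beyond the usual scatter is expected in this assay, and the assay may well report only a limit again. The expected step is a number no higher from compound 1 to compound 3 (the limit leaves the size open). For compound 3 the estimate is 25000 nM, with an expected range from 10000 nM to 50000 nM.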

Compound 3, half-maximal inhibitory concentration: > 25000 nM
Compound 3: a limit, no number; the forecaster's own chance of this, stated with the estimate: 70%; the middle value lies on the limit itself.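

Compound 3 gives a limit and not a number, as does compound 1, so the step between compound 1 and compound 3 cannot be read in this assay. All the compounds shown end alike: the limit of > 25000 nM in this assay, at which 3 of the 3 values shown sit. They leave open whether any change to the shared core gives a readable number in this assay.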